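Swapping the saturated ring of compound 2 for a bromophenyl group

This account rests on a few compounds, and the source may have more. Where it says the series, first, only, none or still open, it means among the compounds named here.

Compound 2, `FC(F)(F)c1cc(NC[C@@H]2CCCCN2)c2cn[nH]c2c1`, is the stronger of the two measured compounds in an assay for inhibition of Indoleamine 2,3-dioxygenase 1 (Homo sapiens), with stated times of 10 min and 60 min, tested at 100 uM; a lower number here means a weaker effect, a higher number a stronger effect of the compound at the concentration tested: compound 2 gives 81%. Compound 1, `FC(F)(F)c1cccc(CNc2cc(C(F)(F)F)cc3[nH]ncc23)c1`, gives 49% in this assay, a number that lies beyond the usual scatter below that of compound 2. Among the compounds with values here, no single-point step between these two is given, so only their two values speak.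

Compound 3, `FC(F)(F)c1cc(NCc2cccc(Br)c2)c2cn[nH]c2c1`, is not yet measured. It is obtained from compound 2 by the change (3-bromophenyl in place of piperidin-2-yl on a saturated chain carbon bound to a nitrogen on an aromatic ring). Since compound 1 also bears an aromatic ring on that chain carbon and gives 49%, the step is expected to be downward and beyond the scatter, with an expected drop of a number 26 percentage points lower from compound 2 to compound 3 (beyond the scatter). For compound 3 the estimate in this assay is therefore 55%, with a range from 30% to 78%.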

Compound 3, a percentage reported as inhibition, at one concentration (the size of the read-out at that concentration, not a potency): 51%
For compound 3 the middle estimate is 4 percentage points above the measured one, within the range that was stated.
By their numbers in this assay, from the lowest: compounds 1 and 3 (each within the scatter of the next); then compound 2.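

In this assay, within the data shown here, 3-bromophenyl in place of piperidin-2-yl gives a number 30 percentage points lower from compound 2 to compound 3 (beyond the scatter), the first direct reading of a change at this chain carbon, and it shows that the saturated ring with its nitrogen cannot be replaced by this aromatic ring without a loss of inhibition at the concentration tested. Bromo in place of trifluoromethyl on an aromatic carbon gives a number 2 percentage points higher from compound 1 to compound 3 (within the scatter), so this assay does not separate these two groups on the aromatic ring. No measurement is available that explains either step.

From the compounds shown here alone, it remains open whether the step from compound 2 follows the ring nitrogen or the saturated ring as such, a question that a cyclohexyl group on the same chain carbon would address. Going by these compounds, the part played by the defined stereocentre also remains open, and the mirror-image piperidin-2-yl group would test it.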